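Fluoro on the Phenyl Ring: Expected Cytotoxicity of Compound 3

The compounds below may be only part of what the source reports. "The series", "measured", "known", "first", "only" and "open" are said of these compounds alone.

The study compares two measured compounds in a functional assay on U-937 cells (Homo sapiens) for cytotoxicity; on this read-out higher numbers stand for lower toxicity in this test and lower numbers for higher toxicity in this test. Compound 1 `Clc1ccc(OC(CCn2ccnc2)c2ccccc2)c(Cl)c1` gives 56500 nM in this assay. Compound 2 `FC(F)(F)c1ccc(OC(CCn2ccnc2)c2ccccc2)cc1` gives 86000 nM in this assay; this number is a little higher than that of compound 1, but the two values lie within the scatter of each other, so no order between them can be claimed. Compound 1 thus holds the lower of the two numbers without standing apart from compound 2.

Compound 3 `Fc1ccc(C(CCn2ccnc2)Oc2ccc(Cl)cc2Cl)cc1` has not been measured in this assay. It differs from compound 1 in one place: fluoro in place of hydrogen on an aromatic carbon. Among the compounds with values here, no step between measured compounds tells what this change does to the read-out. Given that compound 1 and compound 2 differ elsewhere and still give values within the scatter, the author expects the step from compound 1 to compound 3 to be small, a 1.1-fold lower number from compound 1 to compound 3 (0.05 log units; within the scatter), with no clear direction beyond the scatter. For compound 3 the estimate is 50000 nM, in the range 20000 nM to 120000 nM.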

Compound 3, half-maximal cytotoxic concentration: 43300 nM
For compound 3 the middle estimate is 1.2-fold (0.06 log units) above the measured one; measured number inside the range.
By their numbers in this assay, from the lowest: compounds 3, 1 and 2 (each within the scatter of the next).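

In this assay, within the data shown here, the step from phenyl to 4-fluorophenyl gives the first direct reading at this place (a 1.3-fold lower number from compound 1 to compound 3 (0.12 log units; within the scatter)), and that step lies within the scatter. Compound 1 and compound 2 differ from each other elsewhere and both carry an unsubstituted phenyl, so they could say nothing about this ring; compound 3 shows that a single fluoro on an aromatic carbon, para to a large group, leaves the number indistinguishable from that of compound 1. With one small substituent and one step, this is a finding about fluoro alone on the core of compound 1, not a rule for the position, and no independent measurement bears on the result.

Going by these compounds, it remains open whether a larger or differently built group at this carbon, such as methoxy, an amine or a carboxylic acid, would move the number beyond the scatter. Also open, on these data alone, is whether the same phenyl to 4-fluorophenyl difference would read alike on the core of compound 2, which carries trifluoromethyl in place of the two chloro groups of compound 1.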